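The source may report more compounds than this note shows. Statements on the series, on what has been measured and on what is new or still open speak of the compounds shown alone.

Among the measured compounds shown here, compound 2 `Cc1cccc(N2C(=O)[C@H]3[C@H](ON4[C@@H]3C(=O)N(C)[C@@]43C[C@H](C)CC[C@H]3C(C)C)C2=O)c1` is one of two compounds measured in a functional assay, read by spectrophotometry, with a stated time of 2 h, tested at 0.5 mg/mL (on this read-out higher numbers stand for a stronger effect at the one concentration tested and lower numbers for a weaker effect), where compound 2 gives 16.1%. For the measured compounds named here, its neighbour, compound 1 `CC(C)[C@@H]1CC[C@@H](C)C[C@@]12N(C)C(=O)[C@@H]1[C@H]3C(=O)N(c4ccccc4)C(=O)[C@H]3ON12`, gives in this assay 14.7%; the step of a number 1.4 percentage points higher from compound 1 to compound 2 (within the scatter) is the only comparison available, and it rests on a methyl in place of hydrogen on an aromatic carbon. Compound 3 `CC(C)[C@@H]1CC[C@@H](C)C[C@@]12N(C)C(=O)[C@@H]1[C@H]3C(=O)N(c4ccc5ccccc5c4)C(=O)[C@H]3ON12` is not yet measured. Its change from compound 2 is naphthalen-2-yl in place of 3-methylphenyl on an amide-type nitrogen in a ring. Going by the values given here, no measured step bears directly on exchanging a single six-membered aromatic ring for two fused ones; the one step known, from compound 1 to compound 2, changed the same aromatic group only slightly and stayed within the scatter. Compound 3 is therefore expected to show a step of a number 0.9 percentage points higher from compound 2 to compound 3 (within the scatter) in this assay, not beyond the scatter in either direction. The estimate for compound 3 in this assay is 17%, with a range from 6% to 30%.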

Compound 3, a percentage reported as activity, at one concentration (the size of the read-out at that concentration, not a potency): 25.4%
Compound 3: middle estimate off by 8.4 percentage points, on the low side, within the range that was stated.
By their numbers in this assay, from the lowest: compounds 1, 2 and 3 (each within the scatter of the next, the first and the last beyond it).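

In this assay, the group on the amide-type nitrogen in a ring turns out to be able to move the read-out, which the small methyl step had not shown: exchanging phenyl for naphthalen-2-yl gives a number 10.7 percentage points higher from compound 1 to compound 3 (beyond the scatter) and is the only step here to clear the scatter. Exchanging 3-methylphenyl for naphthalen-2-yl gives a number 9.3 percentage points higher from compound 2 to compound 3 (within the scatter), so the gain is established against phenyl only, and modestly. Nothing measured here accounts for the step.

On these data alone, it remains open whether a nitrogen-containing aromatic group such as quinolinyl or pyridinyl, or a non-aromatic group such as cyclohexyl, would sit with naphthalen-2-yl or with phenyl. Also open, as far as these compounds go, is what an amine or a carboxylic acid on the aromatic ring would do at this position.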